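Compound 3 to compound 4: butyl to tert-butyl

The source may report more compounds than this note shows. Statements on the series, on what has been measured and on what is new or still open speak of the compounds shown alone.

In a functional assay on MT4 cells (Homo sapiens) for antiproliferative activity, read by MTT assay, with a stated time of 96 h (on this read-out lower numbers stand for stronger inhibition and higher numbers for weaker inhibition), compound 1 (`O=C1C2=C(C(=O)c3ncccc31)C1(CS2)NC(=O)N(c2ccccc2)C1=O`) gives 25 nM and compound 3 (`CCCCc1ccc(N2C(=O)NC3(CSC4=C3C(=O)c3ncccc3C4=O)C2=O)cc1`) gives 200 nM, so compound 3 holds the higher of these two single numbers. Compound 2 (`O=C1NC(=O)C2(CSC3=C2C(=O)c2ncccc2C3=O)N1`) has repeated entries (130 nM; 120 nM; 130 nM (3 entries)), and these agree closely (the several entries of compound 2 in this assay, 130 nM; 120 nM; 130 nM (3 entries)).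

Compound 4 (`CC(C)(C)c1ccc(N2C(=O)NC3(CSC4=C3C(=O)c3ncccc3C4=O)C2=O)cc1`) keeps the core of compound 3 and differs only in the para group on the aromatic ring (tert-butyl in place of butyl on an aromatic carbon), with tert-butyl in place of butyl on an aromatic carbon.

Going by the values given here, one measured step bears on this, butyl in place of hydrogen on an aromatic carbon (an 8.0-fold higher number from compound 1 to compound 3 (0.90 log units; beyond the scatter)). That step lies beyond the scatter, but it shows only what adding butyl did. Among the compounds with values here, no measured pair compares butyl with tert-butyl, so the direction stays open and no step beyond the scatter is expected in this assay.

The expected change is small (a 1.2-fold lower number from compound 3 to compound 4 (0.07 log units; within the scatter)). For compound 4 the estimated value is 170 nM (expected range 60 nM to 450 nM).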

Compound 4, half-maximal inhibitory concentration: 200 nM
Estimate against measurement, compound 4: 1.2-fold (0.07 log units) below; the range from low to high includes it.
By their numbers in this assay, from the lowest: compound 1; then compounds 3 and 4 (each within the scatter of the next).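

In this assay, the arrangement of the group para to a large group makes no visible difference for this pair: tert-butyl in place of butyl gives no change at the digits printed from compound 3 to compound 4 (within the scatter). Set against the hydrogen of compound 1, the branched group gives an 8.0-fold higher number from compound 1 to compound 4 (0.90 log units; beyond the scatter), matching the linear group's an 8.0-fold higher number from compound 1 to compound 3 (0.90 log units; beyond the scatter), so the weakening is not peculiar to the straight chain. Repeat readings in this assay sit close together, which supports reading the 3>4 pair as flat: the several entries of compound 2 in this assay, 130 nM; 120 nM; 130 nM (3 entries)

On these data alone, only hydrogen, butyl and tert-butyl stand at this position, so it remains open how the number moves between hydrogen and these larger groups. A methyl group, or an amine or carboxylic acid in the same place, would show whether the weakening follows chain size or holds for any group here.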